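One Inverted Ring Centre Above a Weak Starting Point

A few compounds are considered here, and "the series" means these few. Any claim that something is new, unique, unknown or untested is made for them only; others in the source may bear on it.

For the measured compounds named here, compound 3 `CC(C)C[C@@H]1O[C@H](COCc2ccccc2)[C@@H](OCc2ccccc2)[C@H](OCc2ccccc2)[C@H]1O` is the only member of this set with a number to its name: in a functional assay on HL-60 cells (Homo sapiens) for antiproliferative activity, read by MTT assay (on this read-out lower numbers stand for stronger inhibition and higher numbers for weaker inhibition), compound 3 gives 8500 nM. Compound 1 `C=CC[C@@H]1O[C@H](COCc2ccccc2)[C@@H](OCc2ccccc2)[C@H](OCc2ccccc2)[C@@H]1O` in this assay gives "not active" (no number reported), and compound 2 `CC(C)C[C@H]1O[C@H](COCc2ccccc2)[C@@H](OCc2ccccc2)[C@H](OCc2ccccc2)[C@@H]1O` in this assay gives "not active" (no number reported). Configuration alone seems to decide the outcome, because the fact that compounds 2 and 3 differ only in the configuration as drawn and yet only compound 3 carries a measurable value. Compound 4 `CC(C)C[C@@H]1O[C@H](COCc2ccccc2)[C@@H](OCc2ccccc2)[C@H](OCc2ccccc2)[C@@H]1O` poses the same question once more: the two compounds have the same atoms and bonds and differ only in configuration as drawn: 1 of 5 stereo elements differ; a stereocentre at a saturated ring carbon is drawn S in compound 3 and R in compound 4. Going by the values given here, no measured step of this kind exists, so the account expects a change beyond the scatter toward weaker inhibition in this assay, with a real chance that no number is reported at all. Compound 4 is estimated at 15000 nM, ranging from 5000 nM to 50000 nM. The expected step is a 1.8-fold higher number from compound 3 to compound 4 (0.25 log units; within the scatter).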

Compound 4, half-maximal inhibitory concentration: "not active" (no number reported)
For compound 4 the study gives words and no number; there is nothing to compare the estimate with.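

For the compounds shown here, with words and no number for compound 4, no step from compound 3 to compound 4 can be read in this assay. The compounds shown leave open how far that single inverted ring centre shifts the value.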